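The source may report more compounds than this note shows. Statements on the series, on what has been measured and on what is new or still open speak of the compounds shown alone.

Measured in a functional assay on HCT-116 cells (Homo sapiens) for inhibition, read by MTT assay, with a stated time of 72 h; on this read-out higher numbers stand for weaker inhibition and lower numbers for stronger inhibition:
Compound 1 `O=C(NO)c1ccc(CNCc2nc(-c3ccccc3)no2)cc1`: 29300 nM
Compound 2 `O=C(NO)c1ccc(CNCc2nc(-c3ccc(Cl)cc3)no2)cc1`: 30200 nM
Compound 3 `O=C(NO)c1ccc(CNCc2nc(-c3ccc([N+](=O)[O-])cc3)no2)cc1`: 21900 nM

Compound 3 stands level with the other two, as the steps of a 1.3-fold lower number from compound 1 to compound 3 (0.13 log units; within the scatter) and a 1.4-fold lower number from compound 2 to compound 3 (0.14 log units; within the scatter) show. Compound 4 `O=C(NO)c1ccc(CNCc2nc(-c3cccs3)no2)cc1` carries thiophen-2-yl in place of 4-nitrophenyl on an aromatic carbon. The closest evidence comes from swaps among hydrogen, chloro and nitro. Along with those two steps, the third, a 1.0-fold higher number from compound 1 to compound 2 (0.01 log units; within the scatter), also stayed small. As far as these compounds go, none of them exchanged the aromatic ring itself, so this change is untested and the range stays wide. In this assay no shift beyond the scatter is expected, in either direction. The expected step is a 1.1-fold higher number from compound 3 to compound 4 (0.06 log units; within the scatter). For compound 4 the estimated value is 25000 nM, with an expected range of 12000 nM to 50000 nM.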

Compound 4, half-maximal inhibitory concentration: > 100000 nM
Compound 4 ended at the assay's limit (the forecaster's own chance of this, stated with the estimate: 5%); middle value at least 4.0-fold (0.60 log units) away from the limit.
By their numbers in this assay, from the lowest: compounds 3, 1 and 2 (each within the scatter of the next). At a limit, above all of these: compound 4.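

Compound 4 in this assay gives a limit and not a number: the limit of > 100000 nM in this assay, at which 1 of the 4 values shown sits. Swapping hydrogen, chloro and nitro had changed little, but replacing the six-membered aromatic ring at this position does matter: an at least 4.5-fold higher number from compound 3 to compound 4 (0.65 log units; beyond the scatter) and an at least 3.3-fold higher number from compound 2 to compound 4 (0.51 log units; beyond the scatter) and an at least 3.4-fold higher number from compound 1 to compound 4 (0.53 log units; beyond the scatter) all lie beyond the scatter. As far as these compounds go, the ring on this carbon therefore cannot be exchanged freely, although the full size of these steps stays unknown. Still open, from the compounds shown here alone, is how a pyridine ring or a furan ring would read here, and whether an amine or a carboxylic acid on the phenyl ring would shift the value.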